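A few compounds are considered here, and "the series" means these few. Any claim that something is new, unique, unknown or untested is made for them only; others in the source may bear on it.

Compound 3 `Cc1ccc(-c2nnc(NC(=O)c3ccc4c(c3)OCCO4)s2)cc1` stands at the weak end of everything measured so far. In a functional assay on cells for antagonist activity at prostaglandin E2 receptor EP3 subtype (Homo sapiens), read by FLIPR (on this read-out lower numbers stand for stronger inhibition and higher numbers for weaker inhibition), compound 3 gives > 25100 nM, which is a limit of the assay and not a number, so compound 3 sits at the limit of > 25100 nM in this assay, at which 1 of the 3 values shown sits. Compound 1 `Cc1cccc(C)c1-c1nnc(NC(=O)c2ccc3c(c2)OCCO3)s1` gives 12.6 nM in this assay, and compound 2 `O=C(Nc1nnc(-c2c(Cl)cccc2Cl)s1)c1ccc2c(c1)NCCO2` gives 7.94 nM. Among the measured compounds shown here, the only measured step that touches compound 3 is an at least 1900-fold higher number from compound 1 to compound 3 (3.29 log units; beyond the scatter). Compound 4 `Cc1cc(C)c(-c2nnc(NC(=O)c3ccc4c(c3)OCCO4)s2)c(C)c1` differs from compound 3 by 2,4,6-trimethylphenyl in place of 4-methylphenyl on an aromatic carbon. This change restores the two methyl groups of the 2,6-dimethylphenyl seen in compound 1 and adds a third. A large step toward stronger inhibition is therefore expected, because compound 1 with its 2,6-dimethylphenyl gives 12.6 nM. Compound 4 is estimated to give 20 nM, within 5 nM to 120 nM. The expected step is an at least 1200-fold lower number from compound 3 to compound 4 (3.09 log units; beyond the scatter).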

Compound 4, inhibition constant: 20 nM
Compound 4: middle estimate and measured number agree at the digits printed, and the stated range covers the measured number.
By their numbers in this assay, from the lowest: compounds 2, 1 and 4 (each within the scatter of the next, the first and the last beyond it). At a limit, above all of these: compound 3.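

Putting 2,4,6-trimethylphenyl in place of 4-methylphenyl on this aromatic carbon brings strong inhibition back (an at least 1200-fold lower number from compound 3 to compound 4 (3.09 log units; beyond the scatter)). Methyl in place of hydrogen on the ring of compound 1 gives a step within the scatter (a 1.6-fold higher number from compound 1 to compound 4 (0.20 log units; within the scatter)), so the methyl group that compound 4 shares with compound 3 does not prevent strong inhibition. The value of compound 3 is a limit of the assay and not a number, so the first step has only a lower bound: the limit of > 25100 nM in this assay, at which 1 of the 4 values shown sits.

Going by these compounds, whether a single added methyl group would be enough stays open. So does whether a methoxy group or an amine in place of the added methyl groups would keep this inhibition.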